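From compound 3 to a 3,4-dichlorophenyl amide

The source may hold more compounds than are shown below. What is called first, only, known or untested is meant among the compounds shown, and "the series" means these compounds.

compound 1 `COc1cc(/C=C/C(=O)c2cccc(NC(=O)c3c(Cl)cccc3Cl)c2)ccc1O`: 2.48 ug/mL
compound 2 `COc1cc(/C=C/C(=O)c2cccc(NC(=O)c3cc(Cl)cc(Cl)c3)c2)ccc1O`: > 50 ug/mL (a limit)
compound 3 `COc1cc(/C=C/C(=O)c2cccc(N)c2)ccc1O`: 6.02 ug/mL

In a functional assay on Vero cells (Chlorocebus sabaeus) for inhibition (on this read-out higher numbers stand for weaker inhibition and lower numbers for stronger inhibition), compound 3 gives 6.02 ug/mL, the higher of the two true numbers, while compound 1 gives 2.48 ug/mL. Compound 2 reports only a limit, > 50 ug/mL.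

The unmeasured compound 4 `COc1cc(/C=C/C(=O)c2cccc(NC(=O)c3ccc(Cl)c(Cl)c3)c2)ccc1O` carries (3,4-dichlorophenyl)carbonyl in place of hydrogen on a nitrogen on an aromatic ring.

Two measured steps make this kind of change, seen in reverse. The first, a 2.4-fold higher number from compound 1 to compound 3 (0.39 log units; beyond the scatter), is modest: removing the 2,6-dichlorophenyl carbonyl raises the number. The second, an at least 8.3-fold lower number from compound 2 to compound 3 (0.91 log units; beyond the scatter), runs the other way and is at least modest. Which dichlorophenyl group is present therefore decides the direction, and the gap is large: an at least 20-fold higher number from compound 1 to compound 2 (1.30 log units; beyond the scatter). Among the compounds with values here, with only two examples, the direction for compound 4 is uncertain. The name 3,4-dichlorophenyl shares a number with 3,5-dichlorophenyl and none with 2,6-dichlorophenyl, so compound 2 at > 50 ug/mL is the closer guide, and weaker inhibition seems more likely. The expected step is a 3.0-fold higher number from compound 3 to compound 4 (0.48 log units; beyond the scatter), towards a higher number. For compound 4 the estimated value is 18 ug/mL, with an expected range of 4 ug/mL to 50 ug/mL.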

Compound 4, half-maximal inhibitory concentration: > 50 ug/mL
Compound 4 gave a limit, no number; the forecaster's own chance of this, stated with the estimate: 30%; middle value at least 2.7-fold (0.44 log units) from the limit.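

Compound 2 no longer stands alone: in this assay, putting (3,4-dichlorophenyl)carbonyl in place of hydrogen on the nitrogen gives an at least 8.3-fold higher number from compound 3 to compound 4 (0.91 log units; beyond the scatter), so a second amide on this nitrogen is clearly weaker than the free amine. Moving the chlorines alone has a larger effect, with 3,4-dichlorophenyl in place of 2,6-dichlorophenyl on the carbonyl carbon giving an at least 20-fold higher number from compound 1 to compound 4 (1.30 log units; beyond the scatter), which leaves compound 1 as the only one of the three dichlorophenyl amides that goes against this loss of inhibition. Compound 2 and compound 4 both end at a limit rather than a number, so the step between them cannot be read and their two groups cannot be ranked against each other: the limit of > 50 ug/mL in this assay, at which 2 of the 4 values shown sit.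

The compounds shown leave open whether a plain benzoyl or an acetyl group on this nitrogen would behave like the group in compound 1 or like those in compound 2 and compound 4. On these data alone, it also remains open whether the inhibition of compound 1 would survive a 2,6-dimethylphenyl group in place of its 2,6-dichlorophenyl.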